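A few compounds are considered here, and "the series" means these few. Any claim that something is new, unique, unknown or untested is made for them only; others in the source may bear on it.

Of the compounds shown here, two have so far been measured in an assay on cell membranes from spleen (Cavia porcellus) for binding affinity to leukotriene B4 receptor 1 (Homo sapiens); on this read-out higher numbers stand for weaker inhibition and lower numbers for stronger inhibition. Compound 1, `COC(=O)CCCCCOc1cc(-c2ccccc2)cc(-c2ccccc2)n1`, carries a methyl ester at the end of its chain, and in this assay compound 1 gives 40 nM, the lower of the two numbers recorded. Compound 2, `O=C(O)CCCCCOc1cc(-c2ccccc2Cl)cc(-c2ccccc2)n1`, carries a free acid at the chain end and a chlorine on one of its two phenyl rings; in this assay compound 2 gives 200 nM, a weaker result than that of compound 1, and the gap between them lies beyond the usual scatter. Compound 2 differs from compound 1 in two places at once, so its number cannot be read as the effect of either change alone.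

Compound 3, `CC(CCCCOc1cc(-c2ccccc2)cc(-c2ccccc2)n1)C(=O)O`, has not yet been measured. Set against compound 1 the change is: 1-carboxyethyl in place of (methoxycarbonyl)methyl on a saturated chain carbon, four bonds along the chain from an oxygen on an aromatic ring. Among the measured compounds shown here, no measured pair shows this change on its own, so the expectation rests only on the two numbers above. A small loss is expected, of the size a 2.5-fold higher number from compound 1 to compound 3 (0.40 log units; beyond the scatter). Compound 3 is therefore estimated at 100 nM, within a range from 25 nM to 400 nM.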

Compound 3, half-maximal inhibitory concentration: 4 nM
Estimate against measurement, compound 3: 25-fold (1.40 log units) above; the whole stated range lies above it.
By their numbers in this assay, from the lowest: compound 3; then compound 1; then compound 2.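

In this assay, 1-carboxyethyl in place of (methoxycarbonyl)methyl on a saturated chain carbon, four bonds along the chain from an oxygen on an aromatic ring, gives a 10-fold lower number from compound 1 to compound 3 (1.00 log units; beyond the scatter), so the result at this position depends strongly on which of these two groups is present. Both groups have the same heavy atoms, so the size of the group alone does not set the number here: what differs is how those atoms are joined, and with that the entering group brings in a hydrogen-bond donor that the leaving group lacks. Nothing measured here explains why the number falls.

As far as these compounds go, the step changes two features at once, turning the methyl ester into a carboxylic acid and placing a methyl branch on the chain, so it remains open which of them carries the gain. An unbranched carboxylic acid on the same core, a methyl ester on the branched chain, and a longer or shorter chain ending in a carboxylic acid would each help to separate these contributions.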